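Moving the trifluoromethyl group around the benzyl ether ring

This account rests on a few compounds, and the source may have more. Where it says the series, first, only, none or still open, it means among the compounds named here.

Measured so far:
compound 1 `CC(C)(N)C(=O)N[C@H](COCc1cccc(Cl)c1Cl)c1nnnn1CCOC(=O)NCCCCO`: 0.61 nM
compound 2 `CC(C)(N)C(=O)N[C@H](COCc1ccccc1C(F)(F)F)c1nnnn1CCOC(=O)NCCCCO`: 0.72 nM

Of the compounds shown here, two built on one shared core have been measured in a functional assay on cells for inhibition of growth hormone secretagogue receptor type 1 (Homo sapiens), read by FLIPR and calcium flux; on this read-out lower numbers stand for an effect already at smaller amounts and higher numbers for an effect only at larger amounts of compound. Compound 1 carries a 2,3-dichlorophenyl group and compound 2 a 2-(trifluoromethyl)phenyl group on a saturated chain carbon bound to an oxygen on a saturated carbon. In this assay, among the measured compounds shown here, compound 2 gives 0.72 nM, the higher of the two numbers, and its only neighbour, compound 1, lies close by: a 1.2-fold higher number from compound 1 to compound 2 (0.07 log units; within the scatter). Compound 3 `CC(C)(N)C(=O)N[C@H](COCc1cccc(C(F)(F)F)c1)c1nnnn1CCOC(=O)NCCCCO` has not yet been measured. It differs from compound 2 in one place: 3-(trifluoromethyl)phenyl in place of 2-(trifluoromethyl)phenyl on a saturated chain carbon bound to an oxygen on a saturated carbon. For the measured compounds named here, the single measured step that bears on this region, the one from compound 1 to compound 2, changed the aromatic substitution pattern on the same phenyl group and stayed within the scatter. On that basis no step beyond the scatter is expected from compound 2 to compound 3, a 1.4-fold higher number from compound 2 to compound 3 (0.14 log units; within the scatter), although a single prior step gives only a loose guide. Compound 3 is therefore estimated to give 1 nM in this assay, within a range from 0.3 nM to 4 nM.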

Compound 3, half-maximal effective concentration: 1.79 nM
Compound 3: middle estimate off by 1.8-fold (0.25 log units), on the low side; low and high end bracket the measured number.
By their numbers in this assay, from the lowest: compounds 1 and 2 (each within the scatter of the next); then compound 3.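

In this assay, where the trifluoromethyl group sits on the phenyl ring makes a measurable difference at this position: with the same atoms joined differently, 3-(trifluoromethyl)phenyl in place of 2-(trifluoromethyl)phenyl gives a 2.5-fold higher number from compound 2 to compound 3 (0.40 log units; beyond the scatter). The exchange of 2,3-dichlorophenyl for 3-(trifluoromethyl)phenyl likewise gives a 2.9-fold higher number from compound 1 to compound 3 (0.47 log units; beyond the scatter), so the step within the scatter between the two earlier compounds does not mean that every change of substitution on this phenyl group leaves the number in place, even though both new steps are modest. Nothing available on these compounds accounts for this difference.

The compounds shown leave open how a plain phenyl group would compare on this saturated chain carbon, and whether a nitrile or a methoxy group in place of trifluoromethyl would show the same dependence on where it sits on the ring. They also leave open whether the step from 2-(trifluoromethyl)phenyl to 3-(trifluoromethyl)phenyl would keep its size if the hydroxyl at the end of the shared chain gave way to a carboxylic acid or an amine.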